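The compounds below may be only part of what the source reports. "The series", "measured", "known", "first", "only" and "open" are said of these compounds alone.

Series notes. Compound 1 `C#CCSc1nc(Sc2nc3ccccc3s2)c(C#N)c(-c2cc(OC)c(OC)c(OC)c2)n1` carries a 1,3-benzothiazol-2-yl on a sulfur whose other neighbour is aromatic carbon. In a functional assay on KYSE-70 cells for antiproliferative activity against KYSE-70 cell line (Homo sapiens), read by MTT assay, with a stated time of 72 h (on this read-out lower numbers stand for stronger inhibition and higher numbers for weaker inhibition), compound 1 gives > 20000 nM, which is a limit of the assay and not a number. Compound 1 therefore stands only at the limit of > 20000 nM in this assay, at which 1 of the 2 values shown sits, without a value of its own. Compound 2 `C#CCSc1nc(Sc2nccs2)c(C#N)c(-c2ccc(Br)cc2)n1` differs from compound 1 in several places. In this assay, among the compounds with values here, compound 2 gives 10900 nM; no single step links these two compounds, so the pair shows only its two values. Compound 3 `C#CCSc1nc(Sc2nc(C)cs2)c(C#N)c(-c2cc(OC)c(OC)c(OC)c2)n1` is not yet measured and differs from compound 1 by 4-methyl-1,3-thiazol-2-yl in place of 1,3-benzothiazol-2-yl on a sulfur. Within the data shown here, no measured step covers this change, and compound 1 itself is a limit, so the expected step of an at least 1.2-fold lower number from compound 1 to compound 3 (0.09 log units; that floor lies within the scatter) is no more than a guess at the weak end of the scale, with no direction beyond the scatter expected. Compound 3 is estimated at 16000 nM, within a range from 6000 nM to 50000 nM.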

Compound 3, half-maximal inhibitory concentration: > 20000 nM
Compound 3 gave a limit, no number; the forecaster's own chance of this, stated with the estimate: 40%; middle value at least 1.2-fold (0.09 log units) away from the limit.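

In this assay compound 3 gives > 20000 nM, a limit and not a number, as compound 1 does, so no step between compound 1 and compound 3 can be read: the limit of > 20000 nM in this assay, at which 2 of the 3 values shown sit.

On these data alone, whether 4-methyl-1,3-thiazol-2-yl in place of 1,3-benzothiazol-2-yl on a sulfur changes activity at all, and in which direction, stays open.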